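Hydrazide cyclopropanes: trimming the aryl ether to trifluoroethyl

The source may report more compounds than this note shows. Statements on the series, on what has been measured and on what is new or still open speak of the compounds shown alone.

Compound 1 `O=C(NNC(=O)C1CC1c1ccc(OC(F)(F)F)cc1)c1ccncc1` gives 37000 nM in a functional assay on U-373MG ATCC cells (Homo sapiens) for inhibition, read by MTT assay, with a stated time of 72 h; a lower number here means a stronger inhibitor, a higher number a weaker inhibitor.
Compound 2 `CC(C)=CCC/C(C)=C/COc1ccc(C2CC2C(=O)NNC(=O)c2ccncc2)cc1` gives 84000 nM in this assay.

Within the data shown here, of the two measured compounds, compound 2 stands with the higher number, the weaker inhibition; its nearest neighbour is compound 1, and the only measured step, a 2.3-fold higher number from compound 1 to compound 2 (0.36 log units; beyond the scatter), separates them. That step swapped 3,7-dimethylocta-2,6-dien-1-yl for trifluoromethyl on the oxygen of the aromatic ring, and the number rose.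

Compound 3 `O=C(NNC(=O)C1CC1c1ccc(OCC(F)(F)F)cc1)c1ccncc1` is not yet measured. It differs from compound 2 by trifluoromethyl in place of 2,6-dimethylhepta-1,5-dien-1-yl on a saturated chain carbon bound to an oxygen on an aromatic ring. This is close to undoing the measured step, while keeping one chain carbon between the oxygen and the trifluoromethyl, so compound 3 sits between compound 1 and compound 2 in shape. Among the measured compounds shown here, the single relevant step, from compound 1 to compound 2, was modest but beyond the scatter, so a drop of similar size is expected here, back toward the number of compound 1, with the change estimated as a 2.1-fold lower number from compound 2 to compound 3 (0.32 log units; beyond the scatter). In this assay compound 3 is therefore expected to give about 40000 nM, within roughly 15000 nM to 110000 nM.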

Compound 3, half-maximal inhibitory concentration: 19000 nM
The estimate for compound 3 lay 2.1-fold (0.32 log units) above the measured number; low and high end bracket the measured number.
By their numbers in this assay, from the lowest: compounds 3 and 1 (each within the scatter of the next); then compound 2.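

In this assay, 2,2,2-trifluoroethyl in place of 3,7-dimethylocta-2,6-dien-1-yl on the oxygen gives a 4.4-fold lower number from compound 2 to compound 3 (0.65 log units; beyond the scatter), so the long chain now stands as the weaker substituent against a second group ending in trifluoromethyl, and not against trifluoromethyl alone. The two small fluorinated ethers, by contrast, cannot be told apart: 2,2,2-trifluoroethyl in place of trifluoromethyl on this oxygen gives a 1.9-fold lower number from compound 1 to compound 3 (0.29 log units; within the scatter), and the added chain carbon therefore has no effect that this assay can resolve. Nothing available here accounts for either result.

The three compounds leave open whether the weaker number of compound 2 goes with the length of its chain or with its double bonds, a question that a saturated 3,7-dimethyloctyl group on the same oxygen would address. They also leave open whether the fluorine atoms matter at all at this position, which a plain ethyl or methyl group on the oxygen would test against compound 3 and compound 1.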